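Swapping chloro for nitro in a tolerated pair

The source may report more compounds than this note shows. Statements on the series, on what has been measured and on what is new or still open speak of the compounds shown alone.

compound 1 `Cc1c(O)nc(SCc2ccc(C#N)cc2)nc1Cc1c(Cl)cccc1Cl` gives > 60000 nM
compound 2 `Cc1c(O)nc(SCc2ccc(Cl)cc2)nc1Cc1c(Cl)cccc1Cl` gives > 59000 nM

In a functional assay on MT4 cells (Homo sapiens) for cytotoxicity, read by MTT assay (a higher number here means that more compound is tolerated, a lower number that less compound is tolerated), compound 2 gives > 59000 nM as its reading, which is a limit and not a number. Compound 1 gives > 60000 nM as its reading, which is also a limit.

Compound 3 `Cc1c(O)nc(SCc2ccc([N+](=O)[O-])cc2)nc1Cc1c(Cl)cccc1Cl` has not been measured. Its difference from compound 2 is nitro in place of chloro on an aromatic carbon and amounts to nitro in place of chloro on an aromatic carbon, para to a large group. For the measured compounds named here, the one measured step that bears on this is a step that the two limits leave unreadable from compound 1 to compound 2 and it also swaps the group at an aromatic carbon. As far as these compounds go, both ends of that step are limits, and its size stays unknown. No step beyond the usual scatter is therefore expected in this assay and another limit is the likeliest reading. The estimate means an expected at least 1.0-fold lower number from compound 2 to compound 3 (0.03 log units; that floor lies within the scatter) of modest size. For compound 3 the estimated value is 55000 nM with an expected range from 20000 nM to 90000 nM around it.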

Compound 3, half-maximal cytotoxic concentration: > 58000 nM
Compound 3: only a limit was reported; the forecaster's own chance of this, stated with the estimate: 70%; middle value at least 1.0-fold (0.02 log units) away from the limit.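

For the compounds shown here, compound 1, compound 2 and compound 3 all give limits and not numbers, and no step among them can be read. The compounds shown leave open what concentration of each the cells fail to tolerate, and whether the cyano, chloro and nitro groups differ at all.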